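Removing the methyl from the piperazine of compound 1

A few compounds are considered here, and "the series" means these few. Any claim that something is new, unique, unknown or untested is made for them only; others in the source may bear on it.

Measured compounds:
compound 1 `Cc1ccc(-[n+]2noc([O-])c2CN2CCN(C)CC2)cc1` gives 100 ug/mL in an ADME assay on HEL cells (Homo sapiens) for cytotoxicity; on this read-out lower numbers stand for higher toxicity in this test and higher numbers for lower toxicity in this test
compound 2 `CN1CCN(Cc2c([O-])on[n+]2-c2ccc(Cc3ccc(-[n+]4noc([O-])c4CN4CCN(C)C(c5ccccc5)C4)cc3)cc2)CC1c1ccccc1` gives 100 ug/mL in this assay
compound 3 `[O-]c1on[n+](-c2ccc(Cc3ccc(-[n+]4noc([O-])c4CN4CCN(c5ccccc5)CC4)cc3)cc2)c1CN1CCN(c2ccccc2)CC1` reports a limit of >= 20 ug/mL in this assay

Compound 1 stands level with compound 2 in this assay, the two values agreeing at the digits shown, within the scatter. The third value belongs to compound 3 and is a limit of the assay rather than a number; it is the limit described in the limit of >= 20 ug/mL in this assay, at which 1 of the 3 values shown sits.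

Compound 4 `Cc1ccc(-[n+]2noc([O-])c2CN2CCNCC2)cc1` has not been measured. It differs from compound 1 in one place: hydrogen in place of methyl on an amine nitrogen in a ring. The change is small, a single carbon leaving and a hydrogen arriving on the amine nitrogen of the six-membered ring. Going by the values given here, no step between two measured compounds is available to show what such a change does in this assay. Given that compound 1 sits at 100 ug/mL and compound 2, with a larger and different substitution, sits at the same value, the account expects no step beyond the scatter for compound 4, in either direction, with the step estimated as no change at the digits printed from compound 1 to compound 4 (within the scatter). Compound 4 is therefore estimated at 100 ug/mL, with a range from 50 ug/mL to 200 ug/mL.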

Compound 4, minimum cytotoxic concentration: 100 ug/mL
The estimate for compound 4 equals the measured number at the digits printed, within the range that was stated.
By their numbers in this assay, from the lowest: compounds 1, 2 and 4 (each within the scatter of the next).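

In this assay, going by these compounds alone, the one step now available between compounds that differ in one place reads no change at the digits printed from compound 1 to compound 4 (within the scatter). Within the data shown here, this gives the first direct reading at this position: the change from 4-methylpiperazin-1-yl to piperazin-1-yl, with hydrogen in place of methyl on an amine nitrogen in a ring, does not move the read-out beyond the scatter, so the methyl is not needed to hold this value. The compounds shown offer no measurement that explains why the step is so small.

As far as these compounds go, a single step at a single position sets no trend, so it stays open whether an acetyl group, a longer chain such as butyl, or a chain ending in a carboxylic acid on this same ring nitrogen would also leave the read-out in place. The value of compound 3 is a limit of the assay and not a number, and compound 3 differs from the others in more than one place, so it adds no step here: the limit of >= 20 ug/mL in this assay, at which 1 of the 4 values shown sits.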